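Mirror Image of Compound 1: Expected Binding Shift

The source may report more compounds than this note shows. Statements on the series, on what has been measured and on what is new or still open speak of the compounds shown alone.

Compound 1 `CCC[C@H](C)n1c(CC)nc2c(-c3ccc(OC(F)(F)F)cc3Cl)nccc21` gives the lower of the two measured numbers in an assay for binding affinity to Corticotropin releasing factor receptor (Rattus norvegicus) (a higher number here means a weaker inhibitor, a lower number a stronger inhibitor), at 2.3 nM. Compound 2 `CCc1nc2c(-c3ccc(Cl)cc3C(F)(F)F)nccc2n1C(CC)C1CC1` gives 4.4 nM in this assay, within the scatter of compound 1. Compound 3 `CCC[C@@H](C)n1c(CC)nc2c(-c3ccc(OC(F)(F)F)cc3Cl)nccc21` differs from compound 1 only in configuration: the two compounds have the same atoms and bonds and differ only in configuration as drawn: 1 of 1 stereo elements differ; a stereocentre at a saturated chain carbon is drawn S in compound 1 and R in compound 3, a stereocentre at a saturated chain carbon drawn S in compound 1 and R in compound 3. Among the compounds with values here, no measured pair shows what such an inversion does; the expectation is a moderately higher number in this assay, so compound 3 is estimated at 12 nM (range 2.5 nM to 80 nM), a step of a 5.2-fold higher number from compound 1 to compound 3 (0.72 log units; beyond the scatter).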

Compound 3, inhibition constant: 1.9 nM
The estimate for compound 3 lay 6.3-fold (0.80 log units) above the measured number; the whole stated range lies above it.
By their numbers in this assay, from the lowest: compounds 3, 1 and 2 (each within the scatter of the next, the first and the last beyond it).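

In this assay, inverting the stereocentre at the saturated chain carbon gives a 1.2-fold lower number from compound 1 to compound 3 (0.08 log units; within the scatter), the first measured view of such an inversion. The S and R forms as drawn therefore cannot be told apart in this assay, at least for this pair. The comparison isolates that one stereocentre: the fact that compounds 1 and 3 differ only in the configuration as drawn

The compounds shown leave open whether the two configurations would stay level if a longer chain or a hydroxyl group were added at this carbon. They also leave open whether this would hold with a different aryl group on the shared core.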